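Notes on an undefined chain stereocentre in compound 3

A few compounds are considered here, and "the series" means these few. Any claim that something is new, unique, unknown or untested is made for them only; others in the source may bear on it.

Values in a functional assay on SW480 cells (Homo sapiens) for antiproliferative activity, read by MTT assay, with a stated time of 48 h; on this read-out lower numbers stand for stronger inhibition and higher numbers for weaker inhibition
Compound 1 `CCCCCCCCCC(CCOS(C)(=O)=O)n1cnc2c(Cl)ncnc21` gives 5390 nM
Compound 2 `CCCCCCCCC[C@H](CCn1cc(-c2ccccc2)nn1)n1cnc2c(Cl)ncnc21` gives 8570 nM
Compound 3 `CCCCCCCCCC(CCn1cc(-c2ccccc2)nn1)n1cnc2c(Cl)ncnc21` has not yet been measured

Among the compounds with values here, only two numbers are available in this assay so far. Compound 2 at 8570 nM lies within the scatter of compound 1, so the two values cannot be told apart.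

The change to compound 3 is the two compounds have the same atoms and bonds; at least one stereo element is drawn with a configuration in one of them and without one in the other: 1 of 1 stereo elements differ; a stereocentre at a saturated chain carbon is drawn R in compound 2 and without a configuration in compound 3 and nothing else. The two compounds have the same atoms and bonds, and a stereocentre at a saturated chain carbon is drawn R in compound 2 and without a configuration in compound 3.

Within the data shown here, no measured pair shows what this stereocentre contributes, so the data offer no direct guide. Among the measured compounds shown here, the only anchor is compound 2 at 8570 nM and no step beyond the scatter is expected in either direction. The expected change is a 1.1-fold lower number from compound 2 to compound 3 (0.03 log units; within the scatter) as estimated here. The estimate for compound 3 is 8000 nM (expected range 4500 nM to 14000 nM).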

Compound 3, half-maximal inhibitory concentration: 9920 nM
Beside the measured number, compound 3's estimate is 1.2-fold (0.09 log units) below it, and the stated range covers the measured number.
By their numbers in this assay, from the lowest: compounds 1, 2 and 3 (each within the scatter of the next).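

In this assay, within the data shown here, the change at the saturated chain carbon from a drawn R configuration to no drawn configuration gives a 1.2-fold higher number from compound 2 to compound 3 (0.06 log units; within the scatter), the first direct reading on this stereocentre, and it shows no separation between the two drawings. That reading carries one qualification: the fact that one of compounds 2 and 3 is drawn with a defined configuration and the other without, at the place where they differ. The second single-place step, 4-phenyl-1H-1,2,3-triazol-1-yl in place of (methylsulfonyl)oxy on a saturated chain carbon, three bonds along the chain from an aromatic nitrogen, gives a 1.8-fold higher number from compound 1 to compound 3 (0.26 log units; within the scatter), so this exchange of chain substituent also shows no separation.

The compounds shown leave open how a compound drawn S at this chain carbon would read in this assay, and therefore whether either configuration differs from the other, as the comparison here sets R only against an undefined drawing. Also open is whether an amine or a carboxylic acid in place of 4-phenyl-1H-1,2,3-triazol-1-yl would give a step beyond the scatter, as neither substituent shown here separates from the other.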